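Lengthening the amide chain of compound 1

The compounds below may be only part of what the source reports. "The series", "measured", "known", "first", "only" and "open" are said of these compounds alone.

Compound 1 `CNC(=O)c1cc(Oc2ccc(NC(=O)c3cc4cccnc4n(-c4ccccc4)c3=O)cc2)ccn1` gives 200 nM in a functional assay on A549 cells (Homo sapiens) for antiproliferative activity, read by MTT assay, with a stated time of 72 h (on this read-out lower numbers stand for stronger inhibition and higher numbers for weaker inhibition), the lowest of the three numbers measured here. Compound 2 `CNC(=O)c1cc(Oc2ccc(NC(=O)c3cc4cccnc4n(-c4ccccc4F)c3=O)cc2)ccn1` gives 610 nM, and compound 3 `CNC(=O)c1cc(Oc2ccc(NC(=O)c3cc4cccnc4n(-c4ccc(C(F)(F)F)cc4Cl)c3=O)cc2)ccn1` gives 2090 nM. Both measured steps from compound 1 lie on the aromatic nitrogen of the shared core: a 3.1-fold higher number from compound 1 to compound 2 (0.48 log units; beyond the scatter), and a 10-fold higher number from compound 1 to compound 3 (1.02 log units; beyond the scatter). Between the other two, a 3.4-fold higher number from compound 2 to compound 3 (0.53 log units; beyond the scatter).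

Compound 4 `CCCNC(=O)c1cc(Oc2ccc(NC(=O)c3cc4cccnc4n(-c4ccccc4)c3=O)cc2)ccn1` differs from compound 1 elsewhere: ethyl in place of hydrogen on a saturated chain carbon bound to an amide-type nitrogen, so methylcarbamoyl becomes propylcarbamoyl. Going by the values given here, no measured step touches this chain; all three changes sit on the aromatic nitrogen. Those steps, from modest to large, show that the read-out answers to substitution at that end, but they give no direction for a longer chain on the amide nitrogen. The expectation for compound 4 is therefore a number near that of compound 1, with a widened range to cover the missing information. The expected step is a 1.5-fold higher number from compound 1 to compound 4 (0.18 log units; within the scatter). Compound 4 is estimated to give 300 nM, between 100 nM and 900 nM.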

Compound 4, half-maximal inhibitory concentration: 95 nM
The estimate for compound 4 lay 3.2-fold (0.50 log units) above the measured number, outside the stated range (below it).
By their numbers in this assay, from the lowest: compound 4; then compound 1; then compound 2; then compound 3.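

Changing methylcarbamoyl to propylcarbamoyl gives a 2.1-fold lower number from compound 1 to compound 4 (0.32 log units; beyond the scatter) in this assay and shows that the read-out also answers to change on the amide nitrogen side of compound 1. The earlier steps, all on the aromatic nitrogen, went only towards higher numbers, whereas this added ethyl is the first change shown that moves towards stronger inhibition. Nothing available here explains why the longer chain gives the lower number.

Propyl is the longest chain shown, so it remains open whether butyl or a longer chain would lower the number further, and whether a chain ending in an amine or a carboxylic acid would behave the same way. From the compounds shown here alone, compound 2 and compound 3 both carry methylcarbamoyl, so it is also open whether propylcarbamoyl would lower their numbers too.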